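The compounds below may be only part of what the source reports. "The series", "measured", "known", "first", "only" and "open" are said of these compounds alone.

Measured so far in a functional assay on MCF7 cells (Homo sapiens), tested at 5 uM; on this read-out lower numbers stand for a stronger effect and higher numbers for a weaker effect at the one concentration tested:
Compound 1 `C=CCOc1c(C)c(C)c2c(c1C)CCC(C)(COc1ccc(/C=C3\SC(=O)NC3=O)cc1OC)O2` gives 5%.
Compound 2 `CC(C)=CCOc1c(C)c(C)c2c(c1C)CCC(C)(COc1ccc(/C=C3\SC(=O)NC3=O)cc1-c1ccc(F)cc1)O2` gives 92%.
Compound 3 `CC(C)=CCOc1c(C)c(C)c2c(c1C)CCC(C)(COc1ccc(/C=C3\SC(=O)NC3=O)cc1)O2` gives 21%.

Compound 3 stands second highest of the three numbers in this assay; compound 1 lies lower, compound 2 far higher. Compound 4 `COc1cc(/C=C2\SC(=O)NC2=O)ccc1OCC1(C)CCc2c(C)c(OCC=C(C)C)c(C)c(C)c2O1` is not yet measured. It differs from compound 3 by methoxy in place of hydrogen on an aromatic carbon. For the measured compounds named here, the only measured step at this aromatic carbon is a number 71 percentage points lower from compound 2 to compound 3 (beyond the scatter), and it shows how strongly the read-out can move there. Compound 1, which carries the same methoxy group, gives 5%, a lower number than compound 3, though the two differ in a second place as well. On that basis a small step downward, within the scatter, is expected, a number 9 percentage points lower from compound 3 to compound 4 (within the scatter). Compound 4 is therefore estimated at 12%, with a range from 0% to 35%.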

Compound 4, a percentage reported as activity, at one concentration (the size of the read-out at that concentration, not a potency): 78%
Beside the measured number, compound 4's estimate is 66 percentage points below it; the measured number lies above the stated range.
By their numbers in this assay, from the lowest: compound 1; then compound 3; then compound 4; then compound 2.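

In this assay methoxy in place of hydrogen on this aromatic carbon gives a number 57 percentage points higher from compound 3 to compound 4 (beyond the scatter) and so shows that a group as small as methoxy can raise the number here, not only 4-fluorophenyl. Methoxy in place of 4-fluorophenyl still gives a number 14 percentage points lower from compound 2 to compound 4 (beyond the scatter) at the same carbon. The low number of compound 1 goes with the other place, since 2-methylprop-1-en-1-yl in place of vinyl gives a number 73 percentage points higher from compound 1 to compound 4 (beyond the scatter) with methoxy present in both. From the compounds shown here alone, whether a hydroxy group or an amine at this aromatic carbon would also raise the number remains open. Nothing at hand gives a cause for these steps.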